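The compounds below may be only part of what the source reports. "The series", "measured", "known", "first", "only" and "open" are said of these compounds alone.

Measured in a functional assay on A549 cells (Homo sapiens) for cytotoxicity, read by MTT assay, with a stated time of 72 h; a higher number here means a weaker inhibitor, a lower number a stronger inhibitor:
- compound 1 `O=C(N/N=C/c1ccc(F)cc1)Nc1cc2c(Nc3ccc(F)c(Cl)c3)ncnc2cc1O[C@H]1CCOC1`: 35100 nM
- compound 2 `O=C(N/N=C/c1cc(Br)c(O)c(Br)c1)Nc1cc2c(Nc3ccc(F)c(Cl)c3)ncnc2cc1O[C@H]1CCOC1`: 8910 nM
- compound 3 `O=C(N/N=C/c1ccc(O)cc1)Nc1cc2c(Nc3ccc(F)c(Cl)c3)ncnc2cc1O[C@H]1CCOC1`: 1320 nM

Compound 1 has the highest number of the three, which makes it the weakest inhibitor here. Compound 4 `COc1cc2ncnc(Nc3ccc(F)c(Cl)c3)c2cc1NC(=O)N/N=C/c1ccc(F)cc1` differs from it by one change, methyl in place of oxolan-3-yl on an oxygen on an aromatic ring.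

Among the compounds with values here, no measured step touches this group. Both a 3.9-fold lower number from compound 1 to compound 2 (0.60 log units; beyond the scatter) and a 27-fold lower number from compound 1 to compound 3 (1.42 log units; beyond the scatter) alter the 4-fluorophenyl group instead, and a 6.8-fold lower number from compound 2 to compound 3 (0.83 log units; beyond the scatter) alters that same part. These steps show that the series can move in this assay, but they give no direction for the new change. No shift beyond the scatter is therefore expected, and the estimated step is a 1.2-fold lower number from compound 1 to compound 4 (0.07 log units; within the scatter). For compound 4 the estimate is 30000 nM, with an expected range of 9000 nM to 70000 nM.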

Compound 4, half-maximal inhibitory concentration: 26600 nM
The estimate for compound 4 lay 1.1-fold (0.05 log units) above the measured number; measured number inside the range.
By their numbers in this assay, from the lowest: compound 3; then compound 2; then compounds 4 and 1 (each within the scatter of the next).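

In this assay the swap of (oxolan-3-yl)oxy for methoxy gives a 1.3-fold lower number from compound 1 to compound 4 (0.12 log units; within the scatter) and so stays within the scatter. Within the data shown here, this is the first reading at this position: with the 4-fluorophenyl group in place, the oxygen on the aromatic ring can lose the ring and its defined stereocentre with no clear change in the number. No available evidence bears on this result.

As far as these compounds go, whether the same swap would hold alongside the 4-hydroxyphenyl group of compound 3 remains open. So does the effect of an ethoxy group or a longer chain ending in an amine on this oxygen.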